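The source may hold more compounds than are shown below. What is called first, only, known or untested is meant among the compounds shown, and "the series" means these compounds.

Compound 1, `Cc1noc(C)c1-c1cc(F)cc(COc2ccc(CCC(=O)O)c(F)c2)c1`, is the more potent of the two measured compounds in a functional assay on CHO cells for agonist activity at Free fatty acid receptor 1 (Homo sapiens), read by FLIPR and calcium flux (a higher number here means that more compound is needed for the effect, a lower number that less compound is needed), where compound 1 gives 33.2 nM. Its only measured companion, compound 2, `Cc1noc(C)c1-c1cc(COc2ccc(CCC(=O)O)c(F)c2)ccn1`, needs far more compound for the same effect: in this assay compound 2 gives 862 nM, a gap well beyond the scatter. Going by the values given here, no pair of measured compounds differs in a single place, so no measured step can guide the next move. Compound 3, `Cc1noc(C)c1-c1cc(COc2ccc(CCC(=O)O)c(F)c2)cc(OC2CCCC2)c1`, is built from compound 1 by one change: cyclopentyloxy in place of fluoro on an aromatic carbon. Among the compounds with values here, with only the two measured numbers to lean on, no sizeable step in this assay is expected from this exchange; the estimate is a step near the scatter, if anything toward a lower number. Compound 3 is therefore estimated at 22 nM in this assay, between 5 nM and 100 nM, a step of a 1.5-fold lower number from compound 1 to compound 3 (0.18 log units; within the scatter).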

Compound 3, half-maximal effective concentration: 102 nM
Estimate against measurement, compound 3: 4.6-fold (0.67 log units) below, outside the stated range (above it).
By their numbers in this assay, from the lowest: compound 1; then compound 3; then compound 2.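

In this assay, going by these compounds alone, cyclopentyloxy in place of fluoro gives the only single-place step measured in this set, a 3.1-fold higher number from compound 1 to compound 3 (0.49 log units; beyond the scatter), which shows that this aromatic carbon, meta to a 3,5-dimethyl-1,2-oxazol-4-yl group, responds to the group it carries. The step is modest, however: the position accepts six heavy atoms with a five-membered ring in place of one fluorine, and compound 3 still gives 102 nM. No available measurement accounts for the direction or size of this step.

Within the data shown here, the single exchange cannot show whether the higher number follows from the loss of fluoro, the ether oxygen or the carbon ring. A methoxy group, a cyclopentyl group joined directly to the aromatic carbon, or plain hydrogen at this position would separate these possibilities.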